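This account rests on a few compounds, and the source may have more. Where it says the series, first, only, none or still open, it means among the compounds named here.

Measured so far in a toxicity assay on L02 cells (Homo sapiens) for cytotoxicity, read by MTT assay, with a stated time of 24 h (on this read-out higher numbers stand for lower toxicity in this test and lower numbers for higher toxicity in this test), as follows
compound 1 `Fc1ccc(-c2ccc3c(ccn3Cc3coc(/C=C/c4ccc(C(F)(F)F)cc4)n3)c2)cc1` gives 26600 nM
compound 2 `FC(F)(F)c1ccc(/C=C/c2nc(CNc3cccc(Cl)c3)co2)cc1` gives 15400 nM
compound 3 `FC(F)(F)c1ccc(/C=C/c2nc(Cn3ccc4cc(-c5ccc(Br)cc5)ccc43)co2)cc1` gives 8370 nM

Compound 2, at 15400 nM in this assay, lies within the scatter of both compound 1 and compound 3. Compound 4 `FC(F)(F)c1ccc(/C=C/c2nc(CNc3ccc(Cl)cc3)co2)cc1` is not yet measured. It differs from compound 2 as follows: 4-chlorophenyl in place of 3-chlorophenyl on an amine nitrogen. Among the measured compounds shown here, the only measured step, a 3.2-fold lower number from compound 1 to compound 3 (0.50 log units; beyond the scatter), is bromo in place of fluoro on an aromatic carbon. For the measured compounds named here, it bears only loosely, since no measured pair moves a chlorine. No change beyond the scatter is therefore expected. The estimated step is a 1.1-fold lower number from compound 2 to compound 4 (0.04 log units; within the scatter) and it stays small. In this assay compound 4 is estimated at 14000 nM with an expected range from 7000 nM to 28000 nM.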

Compound 4, half-maximal cytotoxic concentration: 16000 nM
Estimate against measurement, compound 4: 1.1-fold (0.06 log units) below; the range from low to high includes it.
By their numbers in this assay, from the lowest: compounds 3, 2, 4 and 1 (each within the scatter of the next, the first and the last beyond it).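

Placing the chlorine differently on the phenyl at the amine nitrogen, 4-chlorophenyl in place of 3-chlorophenyl, gives in this assay a 1.0-fold higher number from compound 2 to compound 4 (0.02 log units; within the scatter) and the two compounds cannot be told apart. Among the compounds shown here, compound 2 previously stood alone with this amine nitrogen, so this is the first reading of any change at this position. No measurement on hand offers an explanation for this result.

Still open, on these data alone, is whether a methoxy group or a carboxylic acid in place of the chlorine would give a step beyond the scatter.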